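A few compounds are considered here, and "the series" means these few. Any claim that something is new, unique, unknown or untested is made for them only; others in the source may bear on it.

Measured compounds:
compound 1 `CCCc1c[nH]c2ccc(F)cc12` – > 100 nM
compound 2 `NCC(N)CCc1c[nH]c2ccc(F)cc12` – 26 nM
compound 3 `CNC(=O)CCCc1c[nH]c2ccc(F)cc12` – 95 nM

In an assay on isolated protein for inhibition of Myeloperoxidase (Homo sapiens), read by ELISA, with a stated time of 5 min (a higher number here means a weaker inhibitor, a lower number a stronger inhibitor), compound 1 gives only a limit, (the limit of > 100 nM in this assay, at which 1 of the 3 values shown sits). Among the two numbers shown, compound 3 stands highest, its nearest neighbour being compound 2 at a 3.7-fold higher number from compound 2 to compound 3 (0.56 log units; beyond the scatter). Compound 4 `NC(=O)CCc1c[nH]c2ccc(F)cc12` differs from compound 3 by carbamoyl in place of (methylcarbamoyl)methyl on a saturated chain carbon, two bonds along the chain from an aromatic carbon. Of the measured steps, an at least 1.0-fold lower number from compound 1 to compound 3 (0.02 log units; that floor lies within the scatter) adds an amide-bearing chain to a plain alkyl chain and shows no change beyond the scatter, while an at least 3.8-fold lower number from compound 1 to compound 2 (0.58 log units; beyond the scatter) brings diamines and is at least modest. Shortening the amide chain in compound 4 is therefore expected to leave the number near that of compound 3, with a step of a 1.6-fold higher number from compound 3 to compound 4 (0.20 log units; within the scatter) in this assay. Compound 4 is estimated at 150 nM, within 40 nM to 600 nM.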

Compound 4, half-maximal inhibitory concentration: 34 nM
For compound 4 the middle estimate is 4.4-fold (0.64 log units) above the measured one; measured number outside the range, below it.
By their numbers in this assay, from the lowest: compounds 2 and 4 (each within the scatter of the next); then compound 3. At a limit, above all of these: compound 1.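

In this assay, carbamoyl in place of (methylcarbamoyl)methyl at this saturated chain carbon gives a 2.8-fold lower number from compound 3 to compound 4 (0.45 log units; beyond the scatter), so here the shorter amide chain, not the longer one, has the lower number. An amide chain with no amine also matches the diamine chain within the scatter, at a 1.3-fold higher number from compound 2 to compound 4 (0.12 log units; within the scatter), and an at least 2.9-fold lower number from compound 1 to compound 4 (0.46 log units; beyond the scatter) shows a step beyond the scatter from the plain alkyl chain. That last step rests on compound 1, which is held only at a limit: the limit of > 100 nM in this assay, at which 1 of the 4 values shown sits.

Compound 4 loses chain length and the amide methyl together, and the compounds shown do not separate the two. As far as these compounds go, whether the amide itself matters stays open, as a carboxylic acid or a single primary amine on this short chain would show.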